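The source may report more compounds than this note shows. Statements on the series, on what has been measured and on what is new or still open speak of the compounds shown alone.

In an ADME assay on MRC5 cells (Homo sapiens), read by MTT assay, with a stated time of 72 h (a higher number here means a weaker inhibitor, a lower number a stronger inhibitor), compound 1 `CSc1ncnc2c1c(-c1cccs1)cn2[C@@H]1O[C@H](CO)[C@@H](O)[C@H]1O` gives > 100000 nM, which is a limit of the assay and not a number. Within the data shown here, compound 2 `CNc1ncnc2c1c(-c1ccco1)cn2[C@@H]1O[C@H](CO)[C@@H](O)[C@H]1O` gives 90800 nM, so it holds the only true number so far and offers a single point of reference, with nothing measured to rank it against. The next compound to be tested is compound 3 `CNc1ncnc2c1c(-c1cc3ccccc3o1)cn2[C@@H]1O[C@H](CO)[C@@H](O)[C@H]1O`, which keeps the shared core and the methylamino group of compound 2. It has 1-benzofuran-2-yl in place of furan-2-yl on an aromatic carbon of a five-membered aromatic ring with 1 nitrogen, part of a fused or bridged system of two rings: 1-benzofuran-2-yl in place of furan-2-yl on an aromatic carbon. Among the measured compounds shown here, no measured pair shows what such a change does in this assay, so the expectation is only a loose one. A moderate move towards a lower number is expected, and the estimated change is a 2.3-fold lower number from compound 2 to compound 3 (0.36 log units; beyond the scatter). For compound 3 the expected value is 40000 nM, with an estimated range from 6000 nM to 100000 nM.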

Compound 3, half-maximal inhibitory concentration: 75300 nM
Beside the measured number, compound 3's estimate is 1.9-fold (0.27 log units) below it; low and high end bracket the measured number.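

In this assay, this place, on an aromatic carbon two ring bonds from the ring nitrogen, now has its first measured step: replacing furan-2-yl with 1-benzofuran-2-yl gives a 1.2-fold lower number from compound 2 to compound 3 (0.08 log units; within the scatter). The change brings in a six-membered aromatic ring of carbon only and more heavy atoms, with the count of hydrogen-bond donors and acceptors the same on both sides, yet the two readings cannot be told apart from repeat measurements, so in this one pair the larger ring system is tolerated without a detectable effect. Both readings are high numbers, and the top of the range has already been reached in this small set: the limit of > 100000 nM in this assay, at which 1 of the 3 values shown sits.

The compounds shown leave open whether a group of a different kind at this place, such as an amine, a carboxylic acid or a longer alkyl chain, would move the number beyond the scatter. On these data alone, it also stays open whether the same ring swap would read alike with another group in place of the methylamino group, as compound 1 differs from compound 2 in more than one place and offers no such comparison.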